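Tert-butyl for Pentan-3-yl on a Longer Core

This account rests on a few compounds, and the source may have more. Where it says the series, first, only, none or still open, it means among the compounds named here.

Compound 1 `CCC(CC)c1cc(/C=C/c2cc(O)cc(O)c2)ccc1O` gives 432 nM in a functional assay on HT-22 cells (Mus musculus), read by MTT assay, with a stated time of 24 h; on this read-out higher numbers stand for an effect only at larger amounts of compound and lower numbers for an effect already at smaller amounts
Compound 2 `CC(C)(C)c1cc(/C=C/c2cc(O)cc(O)c2)ccc1O` gives 484 nM in this assay
Compound 3 `CCC(CC)c1cc(/C=C/C=C/c2cc(O)cc(O)c2)ccc1O` gives 79 nM in this assay

Compound 1 and compound 2 share one core and differ in a single place: tert-butyl in place of pentan-3-yl on an aromatic carbon. That change made a 1.1-fold higher number from compound 1 to compound 2 (0.05 log units; within the scatter), so the two compounds cannot be told apart on this read-out.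

Compound 3 is built on a different core. The difference between the two cores is not broken down here. In this assay compound 3 gives the lowest number of the three measured compounds, beyond the scatter from both compound 1 and compound 2.

Compound 4 `CC(C)(C)c1cc(/C=C/C=C/c2cc(O)cc(O)c2)ccc1O` has not yet been measured. It stands to compound 3 as compound 2 stands to compound 1: tert-butyl in place of pentan-3-yl on an aromatic carbon. The place where the group sits is described in the same words for both pairs, so this is the same change on a different core.

Because compound 1 to compound 2 gave a 1.1-fold higher number from compound 1 to compound 2 (0.05 log units; within the scatter), the same change is expected to leave the number close to that of compound 3, and the estimated step is a 1.1-fold higher number from compound 3 to compound 4 (0.06 log units; within the scatter). Compound 4 is therefore expected to give about 90 nM in this assay, with a likely range from 40 nM to 200 nM. This rests on one earlier pair only, so the expectation is loose.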

Compound 4, half-maximal effective concentration: 91 nM
Beside the measured number, compound 4's estimate is 1.0-fold (0.00 log units) below it; measured number inside the range.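

In this assay, putting tert-butyl in place of pentan-3-yl on the core of compound 3 made a 1.2-fold higher number from compound 3 to compound 4 (0.06 log units; within the scatter), so compound 3 and compound 4 cannot be told apart on this read-out. Set beside the earlier pair, the change gave matching results on both cores: the same change on two cores in this assay, a 1.1-fold higher number (0.05 log units; within the scatter) from compound 1 to compound 2 and a 1.2-fold higher number (0.06 log units; within the scatter) from compound 3 to compound 4, 1.0-fold (0.01 log units) apart, within the scatter of two such steps. This shows that, in these two pairs, the choice between the two groups made no measurable difference on either core, but two pairs in one assay do not show that the same would hold on a third core or on another read-out, and they do not explain why the two groups give matching numbers.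

The compounds shown leave open whether a group of a different kind, such as a methyl, a cyclohexyl ring, an amine or a carboxylic acid, would give a similar number when placed on the same aromatic carbon of either core. They also leave open how the number would respond if the hydroxy group ortho to that carbon were replaced by a methoxy group, since every compound shown carries the hydroxy group there.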